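The source may report more compounds than this note shows. Statements on the series, on what has been measured and on what is new or still open speak of the compounds shown alone.

The series shares one core, seen in compound 1 `O=C(/C=C\c1ccccc1O)N1N=C(c2ccncc2)OC1c1c[nH]c2ccccc12`, compound 2 `O=C(/C=C\c1cccc(O)c1)N1N=C(c2ccncc2)OC1c1c[nH]c2ccccc12` and compound 3 `O=C(/C=C\c1ccccc1F)N1N=C(c2ccncc2)OC1c1c[nH]c2ccccc12`; compound 4 `O=C(/C=C\c1ccc(F)cc1)N1N=C(c2ccncc2)OC1c1c[nH]c2ccccc12` has not yet been measured. In an ADME assay on PANC-1 cells (Homo sapiens) for cytotoxicity, read by MTT assay, with a stated time of 48 h (on this read-out higher numbers stand for weaker inhibition of growth and lower numbers for stronger inhibition of growth), compound 2 gives > 30 ug/mL, which is a limit of the assay rather than a number. Compound 1 also gives a limit, > 30 ug/mL. Compound 3 likewise gives a limit, > 30 ug/mL. The change from compound 2 to compound 4 is 4-fluorophenyl in place of 3-hydroxyphenyl on a double-bonded chain carbon bound to a double-bonded chain carbon. The steps a step that the two limits leave unreadable from compound 1 to compound 2, a step that the two limits leave unreadable from compound 1 to compound 3 and a step that the two limits leave unreadable from compound 2 to compound 3 cannot be read, because of the limit of > 30 ug/mL in this assay, at which 3 of the 3 values shown sit. Among the measured compounds shown here, the measured steps therefore give no size and no direction for the step to compound 4; they show only that three variations of the same phenyl ring left the value at the limit. Compound 4 is thus expected to sit at that limit as well, a step that the limit leaves unreadable from compound 2 to compound 4, with an estimate of 45 ug/mL and a range from 15 ug/mL to 150 ug/mL.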

Compound 4, concentration for 50% growth inhibition: > 30 ug/mL
Compound 4 gave a limit, no number (the forecaster's own chance of this, stated with the estimate: 75%); the middle value lies beyond the limit too.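

In this assay compound 4 gives only a limit, as do compound 1, compound 2 and compound 3, so no step among these compounds can be read: the limit of > 30 ug/mL in this assay, at which 4 of the 4 values shown sit. The compounds shown leave open where any of them would fall beyond that limit, and whether any other change on the phenyl ring would give a readable value.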